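Amide tail amine swap on the shared core

The compounds below may be only part of what the source reports. "The series", "measured", "known", "first", "only" and "open" are said of these compounds alone.

Among the measured compounds shown here, compound 2 `COc1cc2ncnc(N3CCc4ccccc43)c2cc1NC(=O)/C=C/CN(C)C` stands lowest of the two numbers so far: in a functional assay on A549 cells (Homo sapiens) for antiproliferative activity, read by MTT assay, with a stated time of 72 h (a lower number here means a stronger inhibitor, a higher number a weaker inhibitor), compound 2 gives 2040 nM, while compound 1 `COc1cc2ncnc(N3CCc4ccccc43)c2cc1NC(=O)C=C(C)C` gives 6270 nM. For the measured compounds named here, the only measured step, a 3.1-fold lower number from compound 1 to compound 2 (0.49 log units; beyond the scatter), also concerns the amide tail. Compound 3 `COc1cc2ncnc(N3CCc4ccccc43)c2cc1NC(=O)/C=C/CN1CCN(C)CC1` carries 4-methylpiperazin-1-yl in place of dimethylamino on a saturated chain carbon bound to a double-bonded chain carbon. Going by the values given here, no measured step covers this swap, and the change from compound 1 to compound 2 was of a different kind. The step from compound 2 to compound 3 is therefore expected to stay small, a 1.1-fold lower number from compound 2 to compound 3 (0.05 log units; within the scatter), with no firm direction. Compound 3 is estimated at 1800 nM, with a range of 600 nM to 5000 nM.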

Compound 3, half-maximal inhibitory concentration: 5360 nM
The estimate for compound 3 lay 3.0-fold (0.47 log units) below the measured number, and the stated range ends below it.
By their numbers in this assay, from the lowest: compound 2; then compounds 3 and 1 (each within the scatter of the next).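

On the saturated chain carbon bound to a double-bonded chain carbon, the amine is not freely interchangeable: in this assay, 4-methylpiperazin-1-yl in place of dimethylamino gives a 2.6-fold higher number from compound 2 to compound 3 (0.42 log units; beyond the scatter). The lower number seen with the dimethylamino tail does not carry over to the 3-(4-methylpiperazin-1-yl)prop-1-en-1-yl tail, which against 2-methylprop-1-en-1-yl gives a 1.2-fold lower number from compound 1 to compound 3 (0.07 log units; within the scatter). No evidence on hand accounts for this difference.

Open, from the compounds shown here alone, is whether morpholin-4-yl or pyrrolidin-1-yl in the same place would track with dimethylamino or with 4-methylpiperazin-1-yl. Going by these compounds, a longer chain carrying the dimethylamino group also remains open.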